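The compounds below may be only part of what the source reports. "The series", "measured", "known", "first", "only" and "open" are said of these compounds alone.

In a functional assay on HepG2 cells (Homo sapiens) for cytotoxicity, with a stated time of 72 h (on this read-out lower numbers stand for an effect already at smaller amounts and higher numbers for an effect only at larger amounts of compound), compound 1 (`C=C[C@@](C)(/C=C/c1ccc(O)cc1)CCC1OC1(C)C`) gives > 52000 nM as a limit of the assay and not a number. Compound 2 (`COc1ccc(/C=C/[C@@](C)(/C=C/c2ccc(O)c(C=O)c2)CCC=C(C)C)cc1`) gives > 26000 nM and this, too, is only a limit. For the measured compounds named here, compound 2 therefore has no exact value, and the one other measured compound offers none to compare with it. Compound 3 (`COc1ccc(/C=C/[C@@](C)(/C=C/c2ccc(O)c(/C=C/C(=O)c3ccccc3)c2)CCC=C(C)C)cc1`) differs from compound 2 in one place, with 2-benzoylethenyl in place of formyl on an aromatic carbon, ortho to a hydroxy group (2-benzoylethenyl in place of formyl on an aromatic carbon). Going by the values given here, no measured step shows what a change of this kind does here, so any forecast is uncertain. A moderate move toward an effect at smaller amounts is expected, estimated as an at least 1.7-fold lower number from compound 2 to compound 3 (0.23 log units; that floor lies within the scatter) in this assay for this single change. For compound 3 the estimated value is 15000 nM with an expected range from 5000 nM to 45000 nM in this measurement.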

Compound 3, half-maximal effective concentration: > 52000 nM
Compound 3: no number, only a limit; the forecaster's own chance of this, stated with the estimate: 30%; middle value at least 3.4-fold (0.53 log units) away from the limit.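

In this assay, for the compounds shown here, compound 2 and compound 3 each give only a limit and not a number, and no step between them can be read. The compounds shown leave open whether 2-benzoylethenyl in place of formyl changes the result in this assay at all.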